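This account rests on a few compounds, and the source may have more. Where it says the series, first, only, none or still open, it means among the compounds named here.

Compound 1 `COc1ccc(/C=C/C(=O)c2ccccc2NC(=O)NS(=O)(=O)c2ccc(C)cc2)cc1OC`: 12.9 ug/mL; compound 2 `Cc1ccc(S(=O)(=O)NC(=O)Nc2ccccc2C(=O)/C=C/c2ccccc2Cl)cc1`: 12.8 ug/mL.

Both numbers come from an ADME assay on the whole organism for cytotoxicity, with Artemia salina as the target, with a stated time of 24 h; on this read-out higher numbers stand for an effect only at larger amounts of compound and lower numbers for an effect already at smaller amounts. Compound 2 holds the lower of the two numbers, yet the step of a 1.0-fold lower number from compound 1 to compound 2 (0.00 log units; within the scatter) lies within the scatter, so the pair is not separated. Compound 3 `Cc1ccc(S(=O)(=O)NC(=O)Nc2ccccc2C(=O)/C=C/c2ccc(Cl)cc2Cl)cc1` differs from compound 2 by chloro in place of hydrogen on an aromatic carbon. Within the data shown here, no measured step mirrors this addition, and the only step in hand, which swapped one aryl group for another, was flat, giving no pull in either direction. For compound 3 the step of a 1.2-fold lower number from compound 2 to compound 3 (0.07 log units; within the scatter) is therefore expected to stay inside the scatter. Compound 3 is estimated at 11 ug/mL, within a range from 5 ug/mL to 25 ug/mL.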

Compound 3, concentration for half-maximal effect: 8.34 ug/mL
Beside the measured number, compound 3's estimate is 1.3-fold (0.12 log units) above it; the measured number falls inside the stated range.
By their numbers in this assay, from the lowest: compounds 3, 2 and 1 (each within the scatter of the next).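

Chloro on this aromatic carbon, meta to a chloro group and para to a large group, brings a 1.5-fold lower number from compound 2 to compound 3 (0.19 log units; within the scatter), so a second chloro on the ring does not separate the pair in this assay. The swap of 3,4-dimethoxyphenyl for 2,4-dichlorophenyl brings a 1.5-fold lower number from compound 1 to compound 3 (0.19 log units; within the scatter), so this aryl change does not separate its pair either. No other measurement bears on these results.

The compounds shown leave open whether an amine or a carboxylic acid on this same aromatic carbon would move the number beyond the scatter.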